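Urea Aryl Exchange Repeated Across a Small Matched Set

The compounds below may be only part of what the source reports. "The series", "measured", "known", "first", "only" and "open" are said of these compounds alone.

Three compounds sharing one core were tested in a functional assay on NCI-H520 cells (Homo sapiens) for inhibition, read by MTT assay, with a stated time of 48 h, tested at 10 uM; a lower number here means less inhibition, a higher number more inhibition at the concentration tested (going by the name of the read-out). Compound 1 `COc1cc(NC(=O)Nc2cc(Nc3ccc(C(C)(C)C)cc3)ncn2)cc(OC)c1` gives 17.5% in this assay. Compound 2 `COc1cc(NC(=O)Nc2cc(Nc3cccc(C(C)(C)C)c3)ncn2)cc(OC)c1` differs from compound 1 by 3-(tert-butyl)phenyl in place of 4-(tert-butyl)phenyl on a nitrogen on an aromatic ring, and in this assay compound 2 gives 13.1%, a step of a number 4.4 percentage points lower from compound 1 to compound 2 (within the scatter). Compound 3 `CC(C)(C)c1ccc(Nc2cc(NC(=O)Nc3c(Cl)cccc3Cl)ncn2)cc1` differs from compound 1 by 2,6-dichlorophenyl in place of 3,5-dimethoxyphenyl on an amide-type nitrogen, and compound 3 gives 22% in this assay, a step of a number 4.5 percentage points higher from compound 1 to compound 3 (within the scatter). All three numbers sit within the scatter of one another, so no order among them can be read.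

Compound 4 `CC(C)(C)c1cccc(Nc2cc(NC(=O)Nc3c(Cl)cccc3Cl)ncn2)c1` has not yet been measured. It differs from compound 2 by 2,6-dichlorophenyl in place of 3,5-dimethoxyphenyl on an amide-type nitrogen. The place lines of the two exchanges read the same word for word, an amide-type nitrogen whose other neighbour is a carbonyl carbon, so this is the same change made a second time. In this assay the expected step is a number 4.4 percentage points higher from compound 2 to compound 4 (within the scatter), resting on the measured step of a number 4.5 percentage points higher from compound 1 to compound 3 (within the scatter). For compound 4 the estimated value in this assay is 17.5%, expected to fall between 8% and 27%.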

Compound 4, a percentage reported as inhibition, at one concentration (the size of the read-out at that concentration, not a potency): 29.6%
Beside the measured number, compound 4's estimate is 12.1 percentage points below it; the measured number lies above the stated range.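

In this assay, 2,6-dichlorophenyl in place of 3,5-dimethoxyphenyl on an amide-type nitrogen gives a step of a number 16.5 percentage points higher from compound 2 to compound 4 (beyond the scatter) on the second core, and the two steps cannot be told apart: the same change on two cores in this assay, a number 4.5 percentage points higher (within the scatter) from compound 1 to compound 3 and a number 16.5 percentage points higher (beyond the scatter) from compound 2 to compound 4, 12 percentage points apart, within the scatter of two such steps. As far as these two pairs go, the exchange carries from the core of compound 1 to the core of compound 2 with the same direction, and nothing here marks the two cores as responding differently. This does not establish a fixed size for the step, as only the second step lies beyond the scatter, and two pairs make no rule for the series.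

The compounds shown leave open whether the same exchange would hold if a carboxylic acid or an amine stood in place of the tert-butyl group. They also leave open how a phenyl ring carrying a single chlorine, or an unsubstituted phenyl, would compare on the amide-type nitrogen, and each reading here is a single-concentration inhibition, not a potency.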